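This account rests on a few compounds, and the source may have more. Where it says the series, first, only, none or still open, it means among the compounds named here.

Measured so far in a functional assay on OVCAR-3 cells (Homo sapiens) for inhibition, read by MTT assay, with a stated time of 24 h; on this read-out lower numbers stand for stronger inhibition and higher numbers for weaker inhibition
- compound 1 `CC1(C)[C@H]2CC[C@]1(C)N(Cc1cn(-c3cccc(C#N)c3)nn1)C(=O)C2` gives 230 nM
- compound 2 `CC1(C)[C@H]2CC[C@]1(C)N(Cc1cn(-c3ccccc3Cl)nn1)C(=O)C2` gives 40 nM
- compound 3 `Cc1ccccc1-n1cc(CN2C(=O)C[C@@H]3CC[C@@]2(C)C3(C)C)nn1` gives 150 nM

Compound 3 cannot be told apart from compound 1 (a 1.5-fold lower number from compound 1 to compound 3 (0.19 log units; within the scatter)), and compound 2 holds the lowest number (a 3.8-fold higher number from compound 2 to compound 3 (0.57 log units; beyond the scatter)). Compound 4 `COc1ccc(-n2cc(CN3C(=O)C[C@@H]4CC[C@@]3(C)C4(C)C)nn2)cc1` has 4-methoxyphenyl in place of 2-methylphenyl on an aromatic nitrogen. Changes at this nitrogen also gave a 5.8-fold lower number from compound 1 to compound 2 (0.76 log units; beyond the scatter); these steps therefore range from within the scatter to modest. Neither compound 1, compound 2 nor compound 3 carries methoxy, so none tests this group directly. The estimated step is a 1.1-fold higher number from compound 3 to compound 4 (0.05 log units; within the scatter), and it is expected to stay within the scatter. For compound 4 the expected value is 170 nM, with an estimated range from 60 nM to 480 nM.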

Compound 4, half-maximal inhibitory concentration: 250 nM
Compound 4: the middle estimate sits 1.5-fold (0.17 log units) below what was measured; measured number inside the range.
By their numbers in this assay, from the lowest: compound 2; then compounds 3, 1 and 4 (each within the scatter of the next).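

Methoxy is now tested for the first time, and 4-methoxyphenyl on this aromatic nitrogen cannot be told apart from 2-methylphenyl (a 1.7-fold higher number from compound 3 to compound 4 (0.22 log units; within the scatter)) or from 3-cyanophenyl (a 1.1-fold higher number from compound 1 to compound 4 (0.04 log units; within the scatter)). Within the data shown here, the 2-chlorophenyl of compound 2 remains the one group that stands clear of the others (a 6.3-fold higher number from compound 2 to compound 4 (0.80 log units; beyond the scatter)).

No measured evidence explains why compound 2 stands apart. From the compounds shown here alone, whether an amine or a carboxylic acid on the phenyl ring would match compound 2 or the other three stays open.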